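Series notes: aryl in place of alkyl on the aromatic nitrogen

The compounds below may be only part of what the source reports. "The series", "measured", "known", "first", "only" and "open" are said of these compounds alone.

Compound 3 `CCCC(CCC)n1c(-c2ccc(OCc3c(-c4c(Cl)cccc4Cl)noc3C(C)C)cc2)nc2ccc(C(=O)O)cc21` gives 30.3 nM in an assay on isolated protein for agonist activity at Bile acid receptor (Homo sapiens), read by TR-FRET; on this read-out lower numbers stand for an effect already at smaller amounts and higher numbers for an effect only at larger amounts of compound. Among the three measured compounds it holds the second highest number; its nearest neighbour is compound 1 `CC(C)c1onc(-c2c(Cl)cccc2Cl)c1COc1ccc(-c2nc3ccc(C(=O)O)cc3n2CC(C)(C)C)cc1`, which in this assay gives 24.8 nM, a gap within the scatter. Compound 2 `CCCn1c(-c2ccc(OCc3c(-c4c(Cl)cccc4Cl)noc3C(C)C)cc2)nc2ccc(C(=O)O)cc21` gives 96.4 nM in this assay and stands furthest from compound 3: the step of a 3.2-fold lower number from compound 2 to compound 3 (0.50 log units; beyond the scatter) lies beyond the scatter.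

Compound 4 `CC(C)c1onc(-c2c(Cl)cccc2Cl)c1COc1ccc(-c2nc3ccc(C(=O)O)cc3n2-c2ccc(F)cc2)cc1` is not yet measured. The change from compound 3 is 4-fluorophenyl in place of 1-propylbutyl on an aromatic nitrogen. All three measured steps touch the same aromatic nitrogen, but with saturated chains only: a 3.9-fold higher number from compound 1 to compound 2 (0.59 log units; beyond the scatter), a 1.2-fold higher number from compound 1 to compound 3 (0.09 log units; within the scatter) and a 3.2-fold lower number from compound 2 to compound 3 (0.50 log units; beyond the scatter). The branched chains of compound 1 and compound 3 gave the lower numbers, the straight propyl of compound 2 the higher one. Going by the values given here, no measured step brings an aromatic ring onto this nitrogen, so the expectation for compound 4 rests on the group size alone. A step of a 1.2-fold higher number from compound 3 to compound 4 (0.06 log units; within the scatter) within the scatter is expected for compound 4. For compound 4 in this assay the estimate is 35 nM, with a range from 10 nM to 130 nM.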

Compound 4, half-maximal effective concentration: 15.1 nM
Compound 4: the middle estimate sits 2.3-fold (0.37 log units) above what was measured; low and high end bracket the measured number.
By their numbers in this assay, from the lowest: compounds 4, 1 and 3 (each within the scatter of the next); then compound 2.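

In this assay, the aromatic nitrogen takes an aromatic ring as well as a saturated chain: replacing the branched chains gives a 2.0-fold lower number from compound 3 to compound 4 (0.30 log units; within the scatter) and a 1.6-fold lower number from compound 1 to compound 4 (0.22 log units; within the scatter), so 4-fluorophenyl stands level with 1-propylbutyl and neopentyl. Only the replacement of the straight chain reads as a change beyond the scatter, with a 6.4-fold lower number from compound 2 to compound 4 (0.81 log units; beyond the scatter) for the same group. No measurement here offers a reason for these steps.

Going by these compounds, what a plain phenyl, a 4-chlorophenyl or a benzyl on this nitrogen would give remains open, so the contribution of the fluorine to this result cannot be read. Also open, on these data alone, is whether the same order of groups would hold with an amide in place of the carboxylic acid on the shared core.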